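Chain extension on the shared core: compound 4

The compounds below may be only part of what the source reports. "The series", "measured", "known", "first", "only" and "open" are said of these compounds alone.

Measured in a functional assay on CHO cells for positive allosteric modulation of metabotropic glutamate receptor 2 (Homo sapiens), read by GTPgammaS binding, with a stated time of 30 min; on this read-out higher numbers stand for larger maximal responses and lower numbers for smaller maximal responses:
compound 1 `CCc1nnc2c(C#N)c(N3CCC(c4ccccc4)CC3)ccn12` — 247%
compound 2 `CCc1nnc2c(Cl)c(N3CCC(c4ccccc4)CC3)ccn12` — 262%
compound 3 `CCc1nnc2c(C(F)(F)F)c(N3CCC(c4ccccc4)CC3)ccn12` — 334%

Compound 3 stands highest of the three numbers; its nearest neighbour is compound 2 and its furthest compound 1, both gaps beyond the scatter. Every measured step sits at the same aromatic carbon: a number 15 percentage points higher from compound 1 to compound 2 (beyond the scatter), a number 87 percentage points higher from compound 1 to compound 3 (beyond the scatter) and a number 72 percentage points higher from compound 2 to compound 3 (beyond the scatter).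

Compound 4 `CCCCc1nnc2c(C(F)(F)F)c(N3CCC(c4ccccc4)CC3)ccn12` keeps the trifluoromethyl group of compound 3 and differs only in the chain: ethyl in place of hydrogen on a saturated chain carbon, two bonds along the chain from an aromatic carbon. Going by the values given here, no measured pair in this set varies that chain; each recorded step concerns the substituent on the aromatic carbon. The three steps give no direct reading on the move from compound 3 to compound 4, and nothing in them says which way the largest response should go. The expectation is accordingly anchored on compound 3, whose 334% is the highest number shown. The step of a number 6 percentage points higher from compound 3 to compound 4 (within the scatter) is expected to stay within the scatter, with a range wide enough to allow movement either way. For compound 4 the estimate in this assay is 340%, with a range from 280% to 400%.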

Compound 4, largest response reached (Emax), in percent of the reference or control that the assay uses: 364%
Beside the measured number, compound 4's estimate is 24 percentage points below it; measured number inside the range.
By their numbers in this assay, from the lowest: compound 1; then compound 2; then compound 3; then compound 4.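

In this assay, going by these compounds alone, the change from ethyl to butyl, with the trifluoromethyl group held fixed, gives a number 30 percentage points higher from compound 3 to compound 4 (beyond the scatter) and is the first step in this set to concern the chain rather than the substituent on the aromatic carbon. It shows that the saturated chain carbon, two bonds along the chain from an aromatic carbon, is also a place where the largest response can move, here upward and by a modest amount. Nothing available bears on why this change raises the number.

This single step leaves open whether the chain change would carry over to the cores holding chloro or cyano on the aromatic carbon, since it has been read only with trifluoromethyl there. It also leaves open how the response develops along the chain, for instance with a longer chain such as hexyl, a branched chain such as isobutyl, or a butyl chain ending in an amine or a carboxylic acid.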